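Adding a second chloro to the chlorophenyl group

The source may report more compounds than this note shows. Statements on the series, on what has been measured and on what is new or still open speak of the compounds shown alone.

Compound 1 `O=S(=O)(/C=C/c1ccc(Cl)c(Cl)c1)Cc1ccc(Nc2ncnc3ccc(Br)cc23)cc1`: 11000 nM
Compound 2 `O=S(=O)(/C=C/c1ccc(Cl)cc1)Cc1ccc(Nc2ncnc3ccc(Br)cc23)cc1`: 2000 nM

Both values come from a functional assay on PC-3 cells (Homo sapiens); on this read-out lower numbers stand for stronger inhibition of growth and higher numbers for weaker inhibition of growth. Compound 2 has the lower of the two numbers, so it is the stronger growth inhibitor of this small pair. The next compound is compound 3 `O=S(=O)(/C=C/c1ccc(Cl)cc1Cl)Cc1ccc(Nc2ncnc3ccc(Br)cc23)cc1`, which differs from compound 2 in one place: chloro in place of hydrogen on an aromatic carbon. Put simply, this is chloro in place of hydrogen on an aromatic carbon, which turns 4-chlorophenyl into 2,4-dichlorophenyl. The new chloro sits ortho to a large group and meta to the chloro group already there.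

Within the data shown here, only one measured step bears on this change. With hydrogen in place of chloro, there was a 5.5-fold lower number from compound 1 to compound 2 (0.74 log units; beyond the scatter). That chloro is not the one added here, so this single step is only a rough guide. Adding a chloro runs in the opposite direction, so a higher number, meaning weaker inhibition, is expected. The estimated move in this assay is a 2.5-fold higher number from compound 2 to compound 3 (0.40 log units; beyond the scatter), probably a somewhat smaller step than the measured one. For compound 3 the estimated value is 5000 nM, with an expected range from 1500 nM to 15000 nM.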

Compound 3, concentration for 50% growth inhibition: 4000 nM
Compound 3: the middle estimate sits 1.3-fold (0.10 log units) above what was measured, within the range that was stated.
By their numbers in this assay, from the lowest: compounds 2 and 3 (each within the scatter of the next); then compound 1.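

In this assay there is a 2.0-fold higher number from compound 2 to compound 3 (0.30 log units; within the scatter), so a chloro on this aromatic carbon, ortho to a large group and meta to the chloro already there, gives no change that can be told apart from the usual scatter of repeated measurements, unlike the step between compound 1 and compound 2, where a 5.5-fold lower number from compound 1 to compound 2 (0.74 log units; beyond the scatter) lies beyond the scatter. The two compounds with a second chloro also differ from each other: with 2,4-dichlorophenyl in place of 3,4-dichlorophenyl there is a 2.8-fold lower number from compound 1 to compound 3 (0.44 log units; beyond the scatter), so in these three compounds the effect of a second chloro depends on where it sits, and not only on its presence. Nothing measured here explains why the two places differ.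

It remains open whether this place would accept other groups in the same way, such as a fluoro, a methyl, a methoxy or an amine, since chloro is the only group shown there. It is also open whether a chloro at this place would give a similar number with the existing chloro removed, as every compound shown keeps that one.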